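Metabolic stability across three acyl sulfonamides and a carbamate analogue

The source may hold more compounds than are shown below. What is called first, only, known or untested is meant among the compounds shown, and "the series" means these compounds.

Compound 1, `CC(C)S(=O)(=O)NC(=O)c1ccc(Nc2nc(NC3(c4ccc(Cl)cc4)CC3)nc(OCC(F)(F)F)n2)cc1`: 96%
Compound 2, `O=C(NS(=O)(=O)C1CC1)c1ccc(Nc2nc(NC3(c4ccc(Cl)cc4)CC3)nc(OCC(F)(F)F)n2)cc1`: 85%
Compound 3, `CNC(=O)NCCS(=O)(=O)NC(=O)c1ccc(Nc2nc(NC3(c4ccc(Cl)cc4)CC3)nc(OCC(F)(F)F)n2)cc1`: 100%

In an ADME assay on microsomes from liver (Rattus norvegicus) for metabolic stability, with a stated time of 10 min (a higher number here means that more of the compound is left, a lower number that less of the compound is left), compound 3 gives the highest of the three numbers: compound 1 sits closest, and the step of a number 4 percentage points higher from compound 1 to compound 3 (within the scatter) lies within the scatter, while the step of a number 15 percentage points higher from compound 2 to compound 3 (beyond the scatter) is beyond it. The two changes measured so far both sit on the sulfonyl sulfur; the step of a number 11 percentage points lower from compound 1 to compound 2 (beyond the scatter) shows the cyclopropyl analogue lower than the isopropyl one.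

Compound 4, `COC(=O)NCCS(=O)(=O)NC(=O)c1ccc(Nc2nc(NC3(c4ccc(Cl)cc4)CC3)nc(OCC(F)(F)F)n2)cc1`, differs from compound 3 in a different place: methoxy in place of methylamino on a carbonyl carbon. No measured step touches the carbonyl carbon of this side chain, so the shown steps give no direct guide. Since compound 3 already stands at the top of the range with 100%, leaving no room for an upward step, the change is expected to give a number 5 percentage points lower from compound 3 to compound 4 (within the scatter), that is, nothing beyond the scatter.

Compound 4 is therefore estimated at 95%, within 82% to 100%.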

Compound 4, percent of the compound remaining: 100%
The estimate for compound 4 lay 5 percentage points below the measured number; the range from low to high includes it.
By their numbers in this assay, from the lowest: compound 2; then compounds 1, 3 and 4 (each within the scatter of the next).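

In this assay, for the compounds shown here, methoxy in place of methylamino on a carbonyl carbon gives no change at the digits printed from compound 3 to compound 4 (within the scatter), the first measured change at this end of the side chain, and it removes a hydrogen-bond donor and brings in a hydrogen-bond acceptor with no visible effect on the number. The 2-((methoxycarbonyl)amino)ethyl group on the sulfonyl sulfur repeats the picture of its methylamino counterpart, with a number 15 percentage points higher from compound 2 to compound 4 (beyond the scatter) and a number 4 percentage points higher from compound 1 to compound 4 (within the scatter). Nothing measured here bears on why the number holds across this swap.

Compound 3 and compound 4 both stand at the top of the range shown, so any difference between them stays hidden at this read-out. From the compounds shown here alone, whether an amine or a carboxylic acid on that carbonyl carbon, or a longer chain to the sulfonyl sulfur, would keep the number there remains open.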